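Chloro in Place of Hydroxy on the Aryl Ring

The source may report more compounds than this note shows. Statements on the series, on what has been measured and on what is new or still open speak of the compounds shown alone.

Measured in an ADME assay on Vero cells (Chlorocebus sabaeus) for inhibition, read by sulforhodamine B assay, with a stated time of 48 h; on this read-out lower numbers stand for stronger inhibition of growth and higher numbers for weaker inhibition of growth:
compound 1, `CC1=CC[C@H](C(C)(C)NC(=S)N/N=C/c2ccccc2)CC1`: 20500 nM
compound 2, `COc1ccc(/C=N/NC(=S)NC(C)(C)[C@H]2CC=C(C)CC2)cc1`: 12200 nM
compound 3, `CC1=CC[C@H](C(C)(C)NC(=S)N/N=C/c2ccccc2O)CC1`: 3100 nM

Of the compounds shown here, three sharing one core have been measured so far, and compound 3 gives the lowest number of the three. Its two steps to the others are both beyond the scatter: a 6.6-fold lower number from compound 1 to compound 3 (0.82 log units; beyond the scatter) and a 3.9-fold lower number from compound 2 to compound 3 (0.59 log units; beyond the scatter). The remaining pair is different in kind, since a 1.7-fold lower number from compound 1 to compound 2 (0.23 log units; within the scatter), so compounds 1 and 2 cannot be placed in any order on these numbers.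

Compound 4, `CC1=CC[C@H](C(C)(C)NC(=S)N/N=C/c2ccccc2Cl)CC1`, is the next compound to be measured. It differs from compound 3 by chloro in place of hydroxy on an aromatic carbon. For the measured compounds named here, no measured step exchanges a hydroxy for a chloro, so the steps that bear on this change are the two that brought the hydroxy in, a 6.6-fold lower number from compound 1 to compound 3 (0.82 log units; beyond the scatter) and a 3.9-fold lower number from compound 2 to compound 3 (0.59 log units; beyond the scatter), both modest and both in the direction of a lower number. Taking the hydroxy away again, even in favour of a chloro rather than a hydrogen, is therefore expected to move the number back up, though compound 4 is not compound 1 and the size of that reversal is open. The expected step is a 2.9-fold higher number from compound 3 to compound 4 (0.46 log units; beyond the scatter). For compound 4 in this assay the estimate is 9000 nM, with a range from 3000 nM to 30000 nM.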

Compound 4, concentration for 50% growth inhibition: 74600 nM
Estimate against measurement, compound 4: 8.3-fold (0.92 log units) below; measured number outside the range, above it.
By their numbers in this assay, from the lowest: compound 3; then compounds 2 and 1 (each within the scatter of the next); then compound 4.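

In this assay, the change of hydroxy to chloro on this aromatic carbon, ortho to a large group, gives a 24-fold higher number from compound 3 to compound 4 (1.38 log units; beyond the scatter), a large step that does more than undo what the hydroxy brought in. The chloro also carries the series past the unsubstituted ring, with a 3.6-fold higher number from compound 1 to compound 4 (0.56 log units; beyond the scatter), and past the 4-methoxyphenyl compound, with a 6.1-fold higher number from compound 2 to compound 4 (0.79 log units; beyond the scatter), so the two groups at this one position now lie on opposite sides of hydrogen, whereas the earlier compounds had shown only a move to lower numbers. Hydroxy, with its hydrogen-bond donor and acceptor, and chloro, with neither, differ in those counts, but nothing measured here explains the gap between them.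

The compounds shown leave open whether the rise follows from losing the hydroxy or from the chlorine atom itself, a question that a 2-fluorophenyl, 2-aminophenyl or 2-methoxyphenyl compound on the same core could help to settle. They also leave open whether chloro or hydroxy would behave the same way elsewhere on the ring, as in the 4-chlorophenyl or 4-hydroxyphenyl compounds.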